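Exchanging the bicyclic amide head group of compound 1

The source may hold more compounds than are shown below. What is called first, only, known or untested is meant among the compounds shown, and "the series" means these compounds.

Compound 1, with the structure `O=C(NCc1ccc(S(=O)(=O)c2ccccc2)cc1)c1cc2ncccc2s1`, is the starting point of this comparison. In a functional assay on A2780 cells (Homo sapiens) for inhibition, read by sulforhodamine B assay, with a stated time of 72 h (on this read-out lower numbers stand for stronger inhibition and higher numbers for weaker inhibition), compound 1 gives > 10000 nM, which is a limit of the assay rather than a measured number. This sits at the limit of > 10000 nM in this assay, at which 1 of the 2 values shown sits, so compound 1 stands at the weak end of the values seen here. Compound 2, with the structure `O=C(NCc1ccc(S(=O)(=O)c2ccc(F)c(F)c2)cc1)c1cc2cnccc2[nH]1`, differs from compound 1 in two places at once, and in this assay compound 2 gives 14 nM.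

The unmeasured compound 3 has the structure `O=C(NCc1ccc(S(=O)(=O)c2ccccc2)cc1)c1nc2cnccc2[nH]1`. It differs from compound 1 by a group of 9 heavy atoms (6 carbon, 3 nitrogen; one five-membered aromatic ring with 2 hetero atoms, one six-membered aromatic ring with 1 hetero atom) in place of a group of 9 heavy atoms (7 carbon, 1 nitrogen, 1 sulfur; one five-membered aromatic ring with 1 hetero atom, one six-membered aromatic ring with 1 hetero atom), on a carbonyl carbon. Among the measured compounds shown here, no single step between measured compounds covers this change, so the size of the step from compound 1 to compound 3 can only be expected, not derived. The writer expects the step from compound 1 to compound 3 to run toward stronger inhibition and to be an at least 12-fold lower number from compound 1 to compound 3 (1.09 log units; beyond the scatter), well beyond the usual scatter. For compound 3 the estimated value in this assay is 800 nM, within an expected range from 50 nM to 10000 nM.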

Compound 3, half-maximal inhibitory concentration: 5400 nM
Estimate against measurement, compound 3: 6.8-fold (0.83 log units) below; low and high end bracket the measured number.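

The exchange of the head group on a carbonyl carbon now has a step of its own in this assay and reads as an at least 1.8-fold lower number from compound 1 to compound 3 (0.26 log units; that floor lies within the scatter) for the ring pair that brings in a five-membered aromatic ring with 2 hetero atoms and 1 hydrogen-bond donor. Compound 1 gives > 10000 nM here, which is a limit of the assay and not a number. The printed step is therefore only a floor that lies within the scatter, and neither a gain beyond the scatter nor the true size of the change can be claimed, because one of its two ends is a limit: the limit of > 10000 nM in this assay, at which 1 of the 3 values shown sits.

Compound 2 differs from compound 3 in more than one place, so the compounds shown do not separate the share of the head group from that of the two fluorines on the phenyl sulfone, and no step can be read for that pair. From the compounds shown here alone, how this head group would read with a single chlorine on that phenyl ring, or with a methyl group on its ring nitrogen, stays open.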